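The compounds below may be only part of what the source reports. "The series", "measured", "known", "first", "only" and "open" are said of these compounds alone.

Measured in an ADME assay on microsomes from liver (Homo sapiens) for metabolic stability (a higher number here means faster removal of the compound, a lower number slower removal), each entry a limit of the assay and not a number:
- Compound 1 `O=C(N[C@H]1CN(S(=O)(=O)c2ccccc2)C[C@@H]1C(=O)N[C@H]1CCCNC1)c1cc(C2CC2)n[nH]1`: < 3 mL.min-1.g-1
- Compound 2 `O=C(N[C@H]1CN(S(=O)(=O)c2ccccc2)C[C@@H]1C(=O)N[C@H]1CCCNC1)c1cc(-c2ccccc2)on1`: < 3 mL.min-1.g-1
- Compound 3 `O=C(N[C@H]1CN(S(=O)(=O)c2ccccc2)C[C@@H]1C(=O)N[C@H]1CCCNC1)c1cc(-c2ccc(Cl)cc2)on1`: < 3 mL.min-1.g-1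

Compound 3 gives < 3 mL.min-1.g-1, which is a limit, so its place in the series cannot be read more finely. The same holds across the set: the limit of < 3 mL.min-1.g-1 in this assay, at which 3 of the 3 values shown sit.

Compound 4 `O=C(N[C@H]1CN(S(=O)(=O)c2ccccc2)C[C@@H]1C(=O)N[C@H]1CCCNC1)c1cc(-c2ccccc2Cl)on1` carries 2-chlorophenyl in place of 4-chlorophenyl on an aromatic carbon, next to the ring oxygen: 2-chlorophenyl in place of 4-chlorophenyl on an aromatic carbon.

The nearest measured change is the chloro in place of hydrogen, a step that the two limits leave unreadable from compound 2 to compound 3. The two changes of the whole group on the carbonyl carbon are a step that the two limits leave unreadable from compound 1 to compound 2 and a step that the two limits leave unreadable from compound 1 to compound 3. None of these gives a size, and none speaks directly to moving the chlorine. Compound 3, with its < 3 mL.min-1.g-1, is therefore the only anchor, and no direction can be argued.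

The estimated step is a step that the limit leaves unreadable from compound 3 to compound 4, with nothing expected beyond the scatter. A limit reading is the likeliest outcome. Compound 4 is expected near 2.5 mL.min-1.g-1, with an estimated range of 1.5 mL.min-1.g-1 to 5 mL.min-1.g-1.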

Compound 4, intrinsic clearance in microsomes: < 3 mL.min-1.g-1
Compound 4 was reported as a limit (the forecaster's own chance of this, stated with the estimate: 75%); the middle value is on the limit's open side.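

Compound 4 sits at the same assay limit as compounds 1, 2 and 3, so no step among these compounds can be read: the limit of < 3 mL.min-1.g-1 in this assay, at which 4 of the 4 values shown sit. From the compounds shown here alone, how the four compounds rank in this assay, and whether 2-chlorophenyl and 4-chlorophenyl differ there at all, stays open.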